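3-Fluorobenzyl to 3-methoxybenzyl in the series

The source may hold more compounds than are shown below. What is called first, only, known or untested is meant among the compounds shown, and "the series" means these compounds.

Among the compounds with values here, in a functional assay on cells (Hepatocyte, Rattus norvegicus) for inhibition, read by scintillation counting, with a stated time of 4 h (a higher number here means a weaker inhibitor, a lower number a stronger inhibitor), compound 1 `O=C(O)C[C@H](O)C[C@H](O)CCn1c(-c2ccc(F)cc2)nc(C(=O)NCc2ccc(F)c(F)c2)c1C1CC1` gives 0.5 nM, and compound 2 `O=C(O)C[C@H](O)C[C@H](O)CCn1c(-c2ccc(F)cc2)nc(C(=O)NCc2cccc(F)c2)c1C1CC1` gives 0.1 nM, the lower of the two numbers so far. Compound 3 `COc1cccc(CNC(=O)c2nc(-c3ccc(F)cc3)n(CC[C@@H](O)C[C@@H](O)CC(=O)O)c2C2CC2)c1` carries methoxy in place of fluoro on an aromatic carbon, meta to a large group (methoxy in place of fluoro on an aromatic carbon). Within the data shown here, only one measured step bears on this change, and it is a different exchange on the same ring: a 5.0-fold lower number from compound 1 to compound 2 (0.70 log units; beyond the scatter). With so little evidence, a modest step towards a higher number in this assay is expected, a 3.0-fold higher number from compound 2 to compound 3 (0.48 log units; beyond the scatter). For compound 3 the estimated value is 0.3 nM, with an expected range of 0.08 nM to 1.2 nM.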

Compound 3, half-maximal inhibitory concentration: 0.2 nM
Compound 3: the middle estimate sits 1.5-fold (0.18 log units) above what was measured, and the stated range covers the measured number.
By their numbers in this assay, from the lowest: compounds 2 and 3 (each within the scatter of the next); then compound 1.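

In this assay, methoxy stands in for fluoro on this aromatic carbon with no change beyond the scatter (a 2.0-fold higher number from compound 2 to compound 3 (0.30 log units; within the scatter)). The advantage over the 3,4-difluorophenyl of compound 1 is therefore not unique to 3-fluorophenyl, since 3-methoxyphenyl also shows it (a 2.5-fold lower number from compound 1 to compound 3 (0.40 log units; beyond the scatter)). Nothing available explains either step.

Open, from the compounds shown here alone, is whether an amine, a hydroxyl or a longer ether such as ethoxy would be accepted on this carbon. Also open, going by these compounds, is whether 3-methoxyphenyl would serve equally with other groups on the shared core.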